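Removing the tert-butyl from the benzyl arm

The source may hold more compounds than are shown below. What is called first, only, known or untested is meant among the compounds shown, and "the series" means these compounds.

Compound 3 `C=C(Br)C(=O)Nc1cccc(/C=C2\SC(=O)N(Cc3ccc(C(C)(C)C)cc3)C2=O)c1` stands second highest of the three numbers in a functional assay on FM3A cells (Mus musculus) for cytotoxicity, read by cell counting, with a stated time of 2 days (a higher number here means a weaker inhibitor, a lower number a stronger inhibitor), where compound 3 gives 5200 nM. Its nearest neighbour is compound 2 `C=C(Br)C(=O)Nc1cccc(/C=C2\SC(=O)N(Cc3ccc(C(F)(F)F)cc3)C2=O)c1`, which gives 870 nM; furthest away is compound 1 `CC(C)(C)c1ccc(CN2C(=O)S/C(=C\c3cccc(N)c3)C2=O)cc1`, which gives 188000 nM. Two measured steps frame compound 3: a 36-fold lower number from compound 1 to compound 3 (1.56 log units; beyond the scatter), and a 6.0-fold higher number from compound 2 to compound 3 (0.78 log units; beyond the scatter). Compound 4 `C=C(Br)C(=O)Nc1cccc(/C=C2\SC(=O)N(Cc3ccccc3)C2=O)c1` differs from compound 3 by hydrogen in place of tert-butyl on an aromatic carbon, on an aromatic carbon of the six-membered carbon-only ring, para to a large group. Among the compounds with values here, only the step from compound 2 to compound 3 bears on this change, since it alters the same ring position; it was modest and beyond the scatter, and it shows that what sits at this position moves this assay. Within the data shown here, no compound without a group at that position has been measured, so the direction for hydrogen is open. A modest step in this assay is expected, with a 1.7-fold lower number from compound 3 to compound 4 (0.24 log units; within the scatter) as the working guess. Compound 4 is therefore estimated at 3000 nM, within 800 nM to 12000 nM.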

Compound 4, half-maximal inhibitory concentration: 810 nM
Compound 4: the middle estimate sits 3.7-fold (0.57 log units) above what was measured, and the stated range covers the measured number.
By their numbers in this assay, from the lowest: compounds 4 and 2 (each within the scatter of the next); then compound 3; then compound 1.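

In this assay, the change from 4-(tert-butyl)phenyl to phenyl gives a 6.4-fold lower number from compound 3 to compound 4 (0.81 log units; beyond the scatter), so a group at this position is not needed to reach the lower numbers of the series. The comparison with trifluoromethyl gives a 1.1-fold lower number from compound 2 to compound 4 (0.03 log units; within the scatter), so hydrogen and trifluoromethyl cannot be told apart here, and among the three groups only tert-butyl stands apart, with the higher number. No measurement available here accounts for this difference.

From the compounds shown here alone, whether an amine, a carboxylic acid or a longer chain at this position would stay level with hydrogen and trifluoromethyl or move towards tert-butyl remains open. Also open, going by these compounds, is whether the gain from the (1-bromoethenyl)carbonyl group on the aromatic nitrogen carries over to the phenyl arm.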